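Swapping the Ring Nitrogen Substituent of Compound 3

The source may report more compounds than this note shows. Statements on the series, on what has been measured and on what is new or still open speak of the compounds shown alone.

In an ADME assay on HeLa cells (Homo sapiens) for cytotoxicity, read by MTT assay, with a stated time of 24 h (a lower number here means a stronger inhibitor, a higher number a weaker inhibitor), three compounds have been measured. Compound 1 `CCN(CC)C(=S)SC(=S)N(C)C` reaches only the limit of the assay, > 5000000 nM, which is a bound and not a number (the limit of > 5000000 nM in this assay, at which 1 of the 3 values shown sits). Compound 2 `CCN(C)C(=S)SC(=S)N(C)C` gives 2070000 nM, and compound 3 `CCOC(=O)N1CCN(C(=S)SC(=S)N(C)C)CC1` gives 530000 nM, the lowest of the two numbers, with compound 2 as its nearest neighbour. Going by the values given here, the one measured step, an at least 2.4-fold lower number from compound 1 to compound 2 (0.38 log units; beyond the scatter), concerns a methyl on a chain carbon bound to an amide-type nitrogen, not the amine nitrogen in a ring where compound 3 and compound 4 differ.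

Compound 4 `CCCCNC(=S)N1CCN(C(=S)SC(=S)N(C)C)CC1` differs from compound 3 by a group of 7 heavy atoms (5 carbon, 1 nitrogen, 1 sulfur; no ring) in place of a group of 5 heavy atoms (3 carbon, 2 oxygen; no ring), on an amine nitrogen in a ring. Among the compounds with values here, no measured step touches this position, so the measured data give no direction for the change. The expectation for compound 4 is therefore a number close to that of compound 3, a step of a 1.3-fold lower number from compound 3 to compound 4 (0.12 log units; within the scatter) that is expected to stay within the scatter. Compound 4 is estimated at 400000 nM in this assay, in a range from 100000 nM to 1600000 nM.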

Compound 4, half-maximal inhibitory concentration: 2840000 nM
The estimate for compound 4 lay 7.1-fold (0.85 log units) below the measured number; the measured number lies above the stated range.
By their numbers in this assay, from the lowest: compound 3; then compounds 2 and 4 (each within the scatter of the next). At a limit, above all of these: compound 1.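

The group on this amine nitrogen in a ring is not a silent part of the molecule: in this assay, replacing ethoxycarbonyl with the group of 7 heavy atoms gives a 5.4-fold higher number from compound 3 to compound 4 (0.73 log units; beyond the scatter), so the number moves towards weaker inhibition. Going by these compounds alone, this is the first measured step at this position, and it gives the position a direction for this one change. The incoming group differs from ethoxycarbonyl in size, in its atoms and in carrying a hydrogen-bond donor, and nothing measured here shows which of these differences accounts for the step.

A single step cannot separate the sulfur, the nitrogen hydrogen and the butyl chain from one another. Going by these compounds, the effect of a urea carrying the same butyl chain, a plain acetyl group or a carboxylic acid on this nitrogen remains open.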